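The source may hold more compounds than are shown below. What is called first, only, known or untested is meant among the compounds shown, and "the series" means these compounds.

Measured in a functional assay on HepG2 cells (Homo sapiens) for cytotoxicity, read by MTT assay, with a stated time of 24 h; on this read-out lower numbers stand for stronger inhibition and higher numbers for weaker inhibition:
- compound 1 `CN1C/C(=C\c2cccnc2)C(=O)/C(=C/c2ccccc2C(F)(F)F)C1`: 2550 nM
- compound 2 `O=C1/C(=C/c2cccnc2)CN(S(=O)(=O)c2ccc(C(F)(F)F)cc2)C/C1=C\c1ccccc1C(F)(F)F`: 1710 nM
- compound 3 `O=C1/C(=C/c2cccnc2)CN(S(=O)(=O)c2ccc(Cl)cc2)C/C1=C\c1ccccc1C(F)(F)F`: 3620 nM

Compound 3 stands at the upper end of these three numbers, with a 1.4-fold higher number from compound 1 to compound 3 (0.15 log units; within the scatter). Compound 4 `O=C1/C(=C/c2cccnc2)CN(S(=O)(=O)c2ccc(Br)cc2)C/C1=C\c1ccccc1C(F)(F)F` carries bromo in place of chloro on an aromatic carbon, para to a large group: bromo in place of chloro on an aromatic carbon. Going by the values given here, the one measured swap on that carbon is a 2.1-fold higher number from compound 2 to compound 3 (0.33 log units; beyond the scatter), a modest step. Among the compounds with values here, no bromo compound has been measured yet, so a smaller step than that one is expected in this assay, with no firm direction. The expected change is a 1.2-fold lower number from compound 3 to compound 4 (0.10 log units; within the scatter), which would stay within the scatter. For compound 4 the estimated value is 2900 nM, with an expected range of 1700 nM to 4900 nM.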

Compound 4, half-maximal inhibitory concentration: 2730 nM
The estimate for compound 4 lay 1.1-fold (0.03 log units) above the measured number; low and high end bracket the measured number.
By their numbers in this assay, from the lowest: compounds 2, 1, 4 and 3 (each within the scatter of the next, the first and the last beyond it).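

In this assay bromo on this aromatic carbon gives a 1.3-fold lower number from compound 3 to compound 4 (0.12 log units; within the scatter) and a 1.6-fold higher number from compound 2 to compound 4 (0.20 log units; within the scatter) so it separates from neither chloro nor trifluoromethyl, although those two lie beyond the scatter of each other. The (4-bromophenyl)sulfonyl group in place of methyl on the amine nitrogen in the ring gives a 1.1-fold higher number from compound 1 to compound 4 (0.03 log units; within the scatter) and so, like the (4-chlorophenyl)sulfonyl group, stays within the scatter. Nothing available explains these numbers.

Still open, from the compounds shown here alone, is whether an amine, a carboxylic acid or a methoxy group on this carbon would move the number beyond the scatter of all three groups seen there.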